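Replacing the 4-nitrophenyl group in compound 1

The source may hold more compounds than are shown below. What is called first, only, known or untested is meant among the compounds shown, and "the series" means these compounds.

In a functional assay on HepG2 cells (Homo sapiens) for cytotoxicity, read by spectrophotometry, with a stated time of 72 h (a lower number here means a stronger inhibitor, a higher number a weaker inhibitor), compound 1 `COc1cc(-n2c(-c3ccc([N+](=O)[O-])cc3)cccc2=O)cc(OC)c1OC` gives < 10 nM, which is a limit of the assay and not a number. Compound 2 `COc1cc(-n2c(-c3ccc(OC(F)(F)F)cc3)cccc2=O)cc(OC)c1OC`, with trifluoromethoxy in place of nitro on an aromatic carbon, gives 1960 nM. This single measured step is an at least 190-fold higher number from compound 1 to compound 2 (2.29 log units; beyond the scatter). Compound 3 `COc1ccc(-c2cccc(=O)n2-c2cc(OC)c(OC)c(OC)c2)cc1C` also loses the nitro group, through (4-methoxy-3-methylphenyl in place of 4-nitrophenyl on an aromatic carbon). Within the data shown here, with compound 2 at 1960 nM as the only guide, a rise beyond the scatter is expected in this assay, perhaps a smaller one. The expected change is an at least 20-fold higher number from compound 1 to compound 3 (1.30 log units; beyond the scatter). Compound 3 is estimated at 200 nM, within an expected range of 25 nM to 1600 nM.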

Compound 3, half-maximal inhibitory concentration: 129 nM
Beside the measured number, compound 3's estimate is 1.6-fold (0.19 log units) above it; the measured number falls inside the stated range.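

In this assay, a second replacement of 4-nitrophenyl, at this place next to the ring nitrogen, gives an at least 12-fold higher number from compound 1 to compound 3 (1.11 log units; beyond the scatter), so both groups without nitro fall short of compound 1. On these data alone, compound 1 gives a limit of the assay and not a number, so the true size of this step stays unknown: the limit of < 10 nM in this assay, at which 1 of the 3 values shown sits. Compound 2 gives 1960 nM and compound 3 gives 129 nM, so the replacing group also matters.

Open, as far as these compounds go, is how an amine or a carboxylic acid would behave in place of nitro. Also open, from the compounds shown here alone, is whether the methoxy or the methyl of compound 3 accounts for its value.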